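Benzylic heteroaryl swap at the amine: compound 3 to compound 4

A few compounds are considered here, and "the series" means these few. Any claim that something is new, unique, unknown or untested is made for them only; others in the source may bear on it.

Measured so far in an assay on CHO cells for displacement of a labelled ligand from adenosine receptor A3 (Homo sapiens), read by scintillation counting, with a stated time of 120 min; a higher number here means a weaker inhibitor, a lower number a stronger inhibitor:
compound 1, `COc1cccc(CNc2nc(N)c3nc(-c4ccc(C)o4)sc3n2)c1`, 160 nM
compound 2, `Nc1nc(NCc2ccncc2)nc2sc(-c3ccco3)nc12`, 827 nM
compound 3, `Nc1nc(NCc2ccco2)nc2sc(-c3ccco3)nc12`, 4.72 nM

Compound 3 holds the lowest number of the three in this assay; compound 1 stands above it and compound 2 highest, both gaps beyond the scatter. Compound 1 differs from compound 3 in more than one place, so only their two values can be compared. One single-site step is available: a 180-fold lower number from compound 2 to compound 3 (2.24 log units; beyond the scatter).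

Compound 4, `Nc1nc(NCc2cccnc2)nc2sc(-c3ccco3)nc12`, is not yet measured. Its difference from compound 3 is pyridin-3-yl in place of furan-2-yl on a saturated chain carbon bound to a nitrogen on an aromatic ring. Among the measured compounds shown here, this change reverses in kind the one measured step, a pyridine ring entering where the furan ring had entered, though a different pyridine isomer is involved, so the size need not match. Given that the step from compound 2 to compound 3 was large, a clear rise is expected here, and the estimated step is an 85-fold higher number from compound 3 to compound 4 (1.93 log units; beyond the scatter). Compound 4 is expected to give about 400 nM in this assay, within a range of 60 nM to 2500 nM.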

Compound 4, inhibition constant: 18.2 nM
The estimate for compound 4 lay 22-fold (1.34 log units) above the measured number; the measured number lies below the stated range.
By their numbers in this assay, from the lowest: compound 3; then compound 4; then compound 1; then compound 2.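

In this assay, pyridin-3-yl in place of furan-2-yl gives a 3.9-fold higher number from compound 3 to compound 4 (0.59 log units; beyond the scatter), so a pyridine ring on this saturated chain carbon can still go with a low number. The pyridine isomer matters strongly here: pyridin-3-yl in place of pyridin-4-yl gives a 45-fold lower number from compound 2 to compound 4 (1.66 log units; beyond the scatter), a much larger step than the change from furan-2-yl to pyridin-3-yl. No measurement is at hand that explains this difference between the isomers.

Still open, on these data alone, is where pyridin-2-yl, an unsubstituted phenyl ring or a saturated ring such as piperidin-4-yl would fall at this place. As far as these compounds go, it is also open whether a longer chain between the amine nitrogen and the ring would preserve the gap between the isomers.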